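Swapping furan for thiophene on the pyrazoline ring

This account rests on a few compounds, and the source may have more. Where it says the series, first, only, none or still open, it means among the compounds named here.

Measured compounds:
compound 1, `O=C(/C=C/c1ccoc1)c1cc(O)c(O)c([N+](=O)[O-])c1`, gives 71400 nM in an assay on isolated protein for inhibition of Amine oxidase [flavin-containing] B (Homo sapiens), read by fluorescence; on this read-out higher numbers stand for weaker inhibition and lower numbers for stronger inhibition
compound 2, `CC(=O)N1N=C(c2cc(O)c(O)c([N+](=O)[O-])c2)CC1c1ccco1`, gives 77400 nM in this assay

Compound 1 and compound 2 share the same nitro-catechol part but differ in how the furan is attached, and they give two numbers that sit within the usual scatter of each other. Going by the values given here, on that basis compound 2 cannot be set apart from compound 1; the two measurements simply agree, and no step between the two compounds can be drawn from them.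

Compound 3, `CC(=O)N1N=C(c2cc(O)c(O)c([N+](=O)[O-])c2)CC1c1cccs1`, has not yet been measured in this assay. It keeps the whole of compound 2 except for one change: thiophen-2-yl in place of furan-2-yl on a saturated ring carbon. Among the compounds with values here, nothing measured so far shows what this kind of exchange does in this assay, so the expectation rests only on the fact that the two rings are alike in size and in what is counted. The step from compound 2 to compound 3 is expected to be small, a 1.3-fold lower number from compound 2 to compound 3 (0.11 log units; within the scatter), and may not reach beyond the scatter in either direction. For compound 3 the estimate is 60000 nM, with a range from 25000 nM to 150000 nM.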

Compound 3, half-maximal inhibitory concentration: 69200 nM
Beside the measured number, compound 3's estimate is 1.2-fold (0.06 log units) below it; low and high end bracket the measured number.
By their numbers in this assay, from the lowest: compounds 3, 1 and 2 (each within the scatter of the next).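

Going by these compounds alone, the first readable step in this set comes from putting thiophen-2-yl in place of furan-2-yl on a saturated ring carbon: this assay shows a 1.1-fold lower number from compound 2 to compound 3 (0.05 log units; within the scatter) and so cannot tell the two compounds apart. At this position, then, one five-membered aromatic ring with one hetero atom can take the place of another, with sulfur instead of oxygen and the same number of heavy atoms, without a change that can be distinguished from repeat-measurement noise. No independent measurement is available to explain this outcome.

The two rings compared here are closely alike, so the compounds shown leave open whether a group of a different kind on that saturated ring carbon, such as an amine, a carboxylic acid or a longer chain, would shift the number beyond the scatter. They also leave open what would happen if the acetyl group were exchanged for another group, such as a longer acyl chain, while the rest of compound 3 stayed the same.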